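Removing a ring methyl on two different cores

The compounds below may be only part of what the source reports. "The series", "measured", "known", "first", "only" and "open" are said of these compounds alone.

Three compounds sharing a common core were tested in a functional assay on HCT-116 cells (Homo sapiens) for inhibition, read by MTT assay, with a stated time of 72 h; a higher number here means a weaker inhibitor, a lower number a stronger inhibitor. Compound 1 `COc1cc2c(Oc3ccc(NC(=O)c4nn(-c5ccc(C)cc5C)cc(C)c4=O)cc3)ccnc2cc1OCCCCCCC(=O)NO` gives 440 nM. Compound 3 `COc1cc2c(Oc3ccc(NC(=O)c4nn(-c5ccc(C)cc5)cc(C)c4=O)cc3)ccnc2cc1OCCCCCCC(=O)NO` differs from compound 1 by hydrogen in place of methyl on an aromatic carbon, and in this assay compound 3 gives 400 nM, so the change gave a 1.1-fold lower number from compound 1 to compound 3 (0.04 log units; within the scatter). Compound 2 `COc1cc2c(Oc3ccc(NC(=O)c4nn(-c5ccccc5C)cc(C)c4=O)c(F)c3)ccnc2cc1OCCCCCCC(=O)NO` gives 2300 nM; the difference between its core and that of compound 1 is not broken down here. Compound 4 `COc1cc2c(Oc3ccc(NC(=O)c4nn(-c5ccccc5C)ccc4=O)c(F)c3)ccnc2cc1OCCCCCCC(=O)NO` differs from compound 2 by hydrogen in place of methyl on an aromatic carbon. This is the same kind of change as that from compound 1 to compound 3, but not the same: there the place was on an aromatic ring of carbon only, ortho to a large group and meta to a methyl group, whereas here it lies on a ring with 2 nitrogen, ortho to a group of 1 heavy atom, meta to a 2-methylphenyl group and opposite the ring nitrogen. Because the earlier step of a 1.1-fold lower number from compound 1 to compound 3 (0.04 log units; within the scatter) was small, compound 4 is expected to show a 1.1-fold higher number from compound 2 to compound 4 (0.04 log units; within the scatter), with wider uncertainty since the place differs. Compound 4 is therefore estimated at 2500 nM, between 900 nM and 7000 nM.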

Compound 4, half-maximal inhibitory concentration: 4390 nM
Beside the measured number, compound 4's estimate is 1.8-fold (0.24 log units) below it, and the stated range covers the measured number.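

In this assay the exchange of methyl for hydrogen on the ring with 2 nitrogen gives a 1.9-fold higher number from compound 2 to compound 4 (0.28 log units; within the scatter) and so stays small, as the earlier step on the other core did. The two steps do not differ when set side by side: the same change on two cores in this assay, a 1.1-fold lower number (0.04 log units; within the scatter) from compound 1 to compound 3 and a 1.9-fold higher number (0.28 log units; within the scatter) from compound 2 to compound 4, 2.1-fold (0.32 log units) apart, within the scatter of two such steps. Among these compounds, this shows that the exchange left the number within the scatter on both cores, but it does not show a rule for the series, since there are only two pairs and the methyl sits on a different ring in each.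

The compounds shown leave open how an ethyl group, a chlorine atom or an amine would fare in place of that methyl. They also leave open whether the same exchange behaves alike on further cores.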